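Thiophenyl-Substituted Silane Expected to Recover Potency

The source may report more compounds than this note shows. Statements on the series, on what has been measured and on what is new or still open speak of the compounds shown alone.

Compound 1 `CCN(C/C=C/C#CC(C)(C)C)Cc1cccc(OC[Si](C)(C)c2ccccc2C(F)(F)F)c1`: 70 nM
Compound 2 `CCN(C/C=C/C#CC(C)(C)C)Cc1cccc(OC[Si](C)(C)c2ccc(S)cc2)c1`: 8000 nM

In a functional assay on liver (Sus scrofa) for inhibition of squalene monooxygenase (Homo sapiens), using microsomes (a higher number here means a weaker inhibitor, a lower number a stronger inhibitor), compound 1 gives 70 nM and compound 2 gives 8000 nM. Among the compounds with values here, compound 2 therefore stands at the weak end of the two numbers, and the single measured step, a 110-fold higher number from compound 1 to compound 2 (2.06 log units; beyond the scatter), is large. Compound 3 `CCN(C/C=C/C#CC(C)(C)C)Cc1cccc(OC[Si](C)(C)c2ccccc2-c2ccsc2)c1` has not yet been measured. It differs from compound 2 in one place: 2-(thiophen-3-yl)phenyl in place of 4-sulfanylphenyl on a silicon. Within the data shown here, only the step from compound 1 to compound 2 bears on this change, and only in part: it shows that the group on the silicon can move the number strongly, and that compound 1, which carries a 2-(trifluoromethyl)phenyl there, gave the lower number. Compound 3 again carries a phenyl substituted in the 2 position, so a large step back toward compound 1 is expected, a 40-fold lower number from compound 2 to compound 3 (1.60 log units; beyond the scatter). Compound 3 is estimated at 200 nM in this assay, within 40 nM to 1500 nM.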

Compound 3, half-maximal inhibitory concentration: 10000 nM
Estimate against measurement, compound 3: 50-fold (1.70 log units) below, outside the stated range (above it).
By their numbers in this assay, from the lowest: compound 1; then compounds 2 and 3 (each within the scatter of the next).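

In this assay, the step to the 2-(thiophen-3-yl)phenyl on the silicon is a 1.3-fold higher number from compound 2 to compound 3 (0.10 log units; within the scatter) and so does not separate it from the 4-sulfanylphenyl. Replacing trifluoromethyl with thiophen-3-yl on the aromatic carbon gives a 140-fold higher number from compound 1 to compound 3 (2.15 log units; beyond the scatter) and shows that the 2-substituted phenyl pattern shared by compound 1 and compound 3 does not by itself keep the lower number, which among these compounds belongs to the 2-(trifluoromethyl)phenyl of compound 1 alone. No available evidence explains this result.

As far as these compounds go, it remains open whether a 2-chlorophenyl or 2-methylphenyl on the silicon would stay close to compound 1 or fall with compound 3. From the compounds shown here alone, it is equally open whether a 2-biphenyl or 2-(thiophen-2-yl)phenyl would give a number like that of compound 3.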